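This account rests on a few compounds, and the source may have more. Where it says the series, first, only, none or still open, it means among the compounds named here.

Compound 1 `O=C1Nc2ccccc2/C1=C/c1ccc(-c2cn(-c3ccccc3Cl)nn2)cc1` carries a 2-chlorophenyl group at one end of a shared core. In a functional assay on MKN-45 cells (Homo sapiens) for inhibition, read by CCK-8 assay, with a stated time of 24 h (a higher number here means a weaker inhibitor, a lower number a stronger inhibitor), compound 1 gives only a limit of the assay, > 20000 nM, so no number is known for it, and this is the limit (the limit of > 20000 nM in this assay, at which 1 of the 3 values shown sits). Compound 2 `N#Cc1ccccc1-n1cc(-c2ccc(/C=C3\C(=O)Nc4ccccc43)cc2)nn1` differs from compound 1 by cyano in place of chloro on an aromatic carbon. In this assay compound 2 gives 14600 nM, which is an at least 1.3-fold lower number from compound 1 to compound 2 (0.13 log units; that floor lies within the scatter). Compound 3 `O=C1Nc2ccc(F)cc2/C1=C/c1ccc(-c2cn(-c3cccc(Cl)c3)nn2)cc1` has a fluorine on its core and a 3-chlorophenyl group; the difference between the core of compound 1 and the core of compound 3 is not broken down here. In this assay compound 3 gives 14100 nM, a value within the scatter of compound 2. Compound 4 `N#Cc1cccc(-n2cc(-c3ccc(/C=C4\C(=O)Nc5ccc(F)cc54)cc3)nn2)c1` is not yet measured. It differs from compound 3 by cyano in place of chloro on an aromatic carbon. This is the same kind of change as that from compound 1 to compound 2, but not the same: there the cyano stands ortho to a large group, here meta to a large group. The earlier change produced an at least 1.3-fold lower number from compound 1 to compound 2 (0.13 log units; that floor lies within the scatter), and a step of similar, small size is expected here. Compound 4 is therefore expected to show a 1.2-fold lower number from compound 3 to compound 4 (0.07 log units; within the scatter) in this assay, resting on the measured at least 1.3-fold lower number from compound 1 to compound 2 (0.13 log units; that floor lies within the scatter). The estimate for compound 4 in this assay is 12000 nM, with a likely range from 5000 nM to 30000 nM.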

Compound 4, half-maximal inhibitory concentration: > 20000 nM
Compound 4: only a limit was reported; the forecaster's own chance of this, stated with the estimate: 25%; middle value at least 1.6-fold (0.22 log units) away from the limit.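

In this assay compound 4 gives > 20000 nM, which is a limit of the assay and not a number. Cyano in place of chloro gives an at least 1.4-fold higher number from compound 3 to compound 4 (0.15 log units; that floor lies within the scatter), and on the core of compound 1 the same kind of change gives an at least 1.3-fold lower number from compound 1 to compound 2 (0.13 log units; that floor lies within the scatter), so each step has only a floor and neither has a known size. The two steps show no clear gain from this change on either core, and they do not show that it carries from one core to the other, or that it fails to, especially as the group does not sit in the same place in the two pairs: the same change on two cores in this assay, an at least 1.3-fold lower number (0.13 log units; that floor lies within the scatter) from compound 1 to compound 2 and an at least 1.4-fold higher number (0.15 log units; that floor lies within the scatter) from compound 3 to compound 4; the limit leaves it open whether they differ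

The true values of compound 1 and compound 4 stay open, and so the full size of both steps stays open too: the limit of > 20000 nM in this assay, at which 2 of the 4 values shown sit. The compounds shown also leave open what an amine, a carboxylic acid or a longer chain in the place of chloro or cyano would give in this assay.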